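The source may hold more compounds than are shown below. What is called first, only, known or untested is meant among the compounds shown, and "the series" means these compounds.

Compound 2 `N/N=C1\NCCN1c1ccccc1` gives 0% in a functional assay on T47D cells (Homo sapiens) for cytotoxicity, with a stated time of 72 h, tested at 50 ug/mL; on this read-out higher numbers stand for a stronger effect at the one concentration tested and lower numbers for a weaker effect. Compound 1 `N/N=C1\NCCN1c1ccccc1Cl` differs from it by chloro in place of hydrogen on an aromatic carbon, and in this assay compound 1 gives 27%, so the change made a number 27 percentage points higher from compound 2 to compound 1 (beyond the scatter). Compound 3 `N=c1c(=O)[nH]nc2n1CCN2c1ccccc1` is built on a different core; the difference between the two cores is not broken down here. In this assay compound 3 gives 3%, and the values of compound 3 and compound 2 lie within the scatter of each other.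

Compound 4 `N=c1c(=O)[nH]nc2n1CCN2c1ccc(Cl)cc1` has not been measured; it differs from compound 3 by chloro in place of hydrogen on an aromatic carbon. Going by the values given here, this is the same kind of change as the one separating compound 2 and compound 1, not the same: there the chloro sits ortho to a group of 7 heavy atoms, here para to a large group. Resting on the single earlier step of a number 27 percentage points higher from compound 2 to compound 1 (beyond the scatter), on a different core and at a different place, the expected step is a number 12 percentage points higher from compound 3 to compound 4 (beyond the scatter), smaller than that one. Compound 4 is therefore estimated to give about 15%, between 0% and 40%.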

Compound 4, a percentage reported as inhibition, at one concentration (the size of the read-out at that concentration, not a potency): 27%
Estimate against measurement, compound 4: 12 percentage points below; low and high end bracket the measured number.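

In this assay, chloro in place of hydrogen on an aromatic carbon gives a number 24 percentage points higher from compound 3 to compound 4 (beyond the scatter), and the step carries over between the two cores at about the same size: the same change on two cores in this assay, a number 27 percentage points higher (beyond the scatter) from compound 2 to compound 1 and a number 24 percentage points higher (beyond the scatter) from compound 3 to compound 4, 3 percentage points apart, within the scatter of two such steps This rests on one pair per core, with the chloro at a different place on the aromatic ring in each pair, so the effects of core and place are not separated. It also does not show that a step of this size would hold on any further core.

Still open, from the compounds shown here alone, is whether a methoxy, an amine or a carboxylic acid on the same ring would give a comparable step. Also open, going by these compounds, is whether chloro gives such a step at other places on that ring.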